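The source may report more compounds than this note shows. Statements on the series, on what has been measured and on what is new or still open speak of the compounds shown alone.

Of the compounds shown here, three sharing one core have been measured in a functional assay on MDA-MB-231 cells (Homo sapiens) for antiproliferative activity, read by MTT assay, with a stated time of 72 h; a higher number here means a weaker inhibitor, a lower number a stronger inhibitor. Compound 1, whose structure is `CC1=CCC2C(CC[C@@]2(C)O)C(C)(C)C1CC[C@@H]1[C@@]2(C)CC[C@@H](O)C(C)(C)O[C@@H]2CC[C@]1(C)O`, carries a free hydroxyl on the ring that bears the ether oxygen. For compound 1 the assay reports only a limit, > 50000 nM, and no number (the limit of > 50000 nM in this assay, at which 1 of the 3 values shown sits). Compound 2, `CC(=O)O[C@H]1CC[C@]2(C)[C@H](CC[C@@](C)(O)[C@H]2CC[C@@H]2C(C)=CC[C@H]3[C@H](CC[C@]3(C)O)C2(C)C)OC1(C)C`, carries an acetoxy group at that position and gives 38000 nM, the higher of the two numbers that were actually read. Compound 3, `CC1=CC[C@H]2[C@@H]1CC=C(C)[C@@H](CC[C@H]1[C@]3(C)CC[C@H](OC(=O)c4ccccc4)C(C)(C)O[C@H]3CC[C@@]1(C)O)C2(C)C`, carries a benzoate ester and a differently unsaturated core, and gives 18400 nM, a lower number than compound 2 by a gap beyond the usual scatter.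

Compound 4, `CC1=CC[C@H]2[C@H](CC[C@]2(C)O)C(C)(C)[C@@H]1CC[C@H]1[C@]2(C)CC[C@H](OC(=O)c3cccc([N+](=O)[O-])c3)C(C)(C)O[C@H]2CC[C@@]1(C)O`, has not yet been measured. It differs from compound 2 in one place: 3-nitrophenyl in place of methyl on a carbonyl carbon. In other words, the acetyl becomes a (3-nitrophenyl)carbonyl group, so the acetoxy of compound 2 becomes a ((3-nitrophenyl)carbonyl)oxy group.

For the measured compounds named here, no single step between measured compounds carries exactly this change. Going by the values given here, the only hint comes from compound 3, whose aromatic ester gave 18400 nM, a number lower than compound 2; its core, however, is not the same. A modest move towards stronger inhibition is therefore expected, with the step from compound 2 to compound 4 estimated at a 1.9-fold lower number from compound 2 to compound 4 (0.28 log units; within the scatter). For compound 4 the expected value in this assay is 20000 nM, with a plausible range from 8000 nM to 50000 nM.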

Compound 4, half-maximal inhibitory concentration: 34700 nM
Compound 4: the middle estimate sits 1.7-fold (0.24 log units) below what was measured, and the stated range covers the measured number.
By their numbers in this assay, from the lowest: compounds 3, 4 and 2 (each within the scatter of the next, the first and the last beyond it). At a limit, above all of these: compound 1.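

In this assay, putting 3-nitrophenyl in place of methyl on a carbonyl carbon gives a 1.1-fold lower number from compound 2 to compound 4 (0.04 log units; within the scatter), so this carbonyl carbon can carry an aromatic ring, with nine heavy atoms entering for one leaving, and the number shows no readable change. Compound 3 could not show this, since its core differs from that of compound 2 as well as its ester, whereas this step changes the ester alone and shows that this particular aromatic ester, on this core, brings no gain over the acetoxy group. Nothing measured here explains why so large an exchange leaves the number in place.

What remains open is whether this holds for aromatic esters in general, since the step covers only 3-nitrophenyl and a plain phenyl on the core of compound 2 is not among the compounds shown. As far as these compounds go, it is also open whether an amine or a carboxylic acid in place of the nitro group, or a longer chain in place of the methyl on the carbonyl carbon, would move the number beyond the scatter.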